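Thiazolyl to Methylpyridinyl on a Naphthylethyl Thiourea

A few compounds are considered here, and "the series" means these few. Any claim that something is new, unique, unknown or untested is made for them only; others in the source may bear on it.

Compound 1 `C[C@H](/N=C(\S)Nc1nccs1)c1cccc2ccccc12` was tested in a functional assay on RBL-2H3 cells (Rattus norvegicus) for inhibition; on this read-out higher numbers stand for weaker inhibition and lower numbers for stronger inhibition. In this assay compound 1 gives only a limit, > 100000 nM, which is the limit of > 100000 nM in this assay, at which 1 of the 3 values shown sits. Compound 2 `C[C@@H](/N=C(\S)Nc1nc2ccccc2s1)c1cccc2ccccc12` gives 18900 nM in this assay, and compound 3 `COc1cc2ncnc(Nc3cc(Br)c(O)c(Br)c3)c2cc1OC`, built on a different core, gives 6800 nM. Among the compounds with values here, no step from compound 1 to either of them is known. Compound 4 `Cc1ccc(N/C(S)=N/[C@@H](C)c2cccc3ccccc23)nc1` has not yet been measured. It differs from compound 1 by 5-methylpyridin-2-yl in place of 1,3-thiazol-2-yl on an amine nitrogen. Within the data shown here, no step of this kind has been measured, so the estimated step of an at least 2.5-fold lower number from compound 1 to compound 4 (0.39 log units; beyond the scatter) is offered as a guess of a gain beyond the scatter in this assay. Compound 4 is therefore expected to give 40000 nM, within a range from 8000 nM to 200000 nM.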

Compound 4, half-maximal inhibitory concentration: > 100000 nM
Compound 4: a limit, no number (the forecaster's own chance of this, stated with the estimate: 45%); at least 2.5-fold (0.39 log units) between middle value and limit.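

Compound 4, like compound 1, gives only a limit, so no step between compound 1 and compound 4 can be read: the limit of > 100000 nM in this assay, at which 2 of the 4 values shown sit.

Left open is whether 5-methylpyridin-2-yl in place of 1,3-thiazol-2-yl changes inhibition at all.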